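This account rests on a few compounds, and the source may have more. Where it says the series, first, only, none or still open, it means among the compounds named here.

Measured compounds:
Compound 1, `Cc1ccc(S(=O)(=O)N2N=C(c3ccc(N4CCN(C)CC4)cc3)CC2c2ccc(N(C)C)cc2)cc1`: 38.1%
Compound 2, `COC(=O)CC(=O)N1N=C(c2ccc(-n3cncn3)cc2)CC1c1ccc(N(C)C)cc1`: 1.5%

Both were tested in a functional assay on NCI-H1975 cells (Homo sapiens) for inhibition, read by sulforhodamine B assay, tested at 10 uM; a higher number here means more inhibition at the concentration tested (going by the name of the read-out), a lower number less inhibition. Of these two numbers, compound 2 stands lowest; its nearest neighbour is compound 1, whose number is higher by a margin well beyond the usual scatter. Compound 3, `Cc1ccc(S(=O)(=O)N2N=C(c3ccc(-n4cncn4)cc3)CC2c2ccc(N(C)C)cc2)cc1`, has not yet been measured. It differs from compound 2 in one place: (4-methylphenyl)sulfonyl in place of ((methoxycarbonyl)methyl)carbonyl on an amine nitrogen in a ring. The group that enters is the same (4-methylphenyl)sulfonyl that compound 1 carries on an amine nitrogen in a ring, and the rest of compound 3 matches compound 2. An upward step is expected in this assay, estimated as a number 23.5 percentage points higher from compound 2 to compound 3 (beyond the scatter), mainly because compound 1 gives 38.1% with that group in place. Compound 3 is thus expected to give about 25%, within a range from 5% to 45%.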

Compound 3, a percentage reported as inhibition, at one concentration (the size of the read-out at that concentration, not a potency): 20%
Compound 3: middle estimate off by 5 percentage points, on the high side, within the range that was stated.
By their numbers in this assay, from the lowest: compound 2; then compound 3; then compound 1.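

In this assay, placing (4-methylphenyl)sulfonyl instead of ((methoxycarbonyl)methyl)carbonyl on the amine nitrogen in the ring gives a number 18.5 percentage points higher from compound 2 to compound 3 (beyond the scatter) and so shows that this position alone can shift the read-out. With that sulfonyl group held fixed, 1H-1,2,4-triazol-1-yl in place of 4-methylpiperazin-1-yl on an aromatic carbon gives a number 18.1 percentage points lower from compound 1 to compound 3 (beyond the scatter) and so shows that the sulfonyl group does not account for the whole number of compound 1, since the group on the aromatic carbon matters too. No measurement available here explains either step.

Among the compounds shown here, each site offers only one comparison, so it remains open how a plain acetyl or a methanesulfonyl on the ring nitrogen would behave. From the compounds shown here alone, a morpholine on the aromatic carbon is equally open, as is whether the two changes simply add together.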